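A few compounds are considered here, and "the series" means these few. Any claim that something is new, unique, unknown or untested is made for them only; others in the source may bear on it.

Measured so far:
compound 1 `CCO/C(O)=C1\C(COCCn2cc(N)n(C)c2=O)=NC(C)=C(C(=O)OC)C1c1ccccc1Cl` — 25.1 nM
compound 2 `CCO/C(O)=C1\C(COCCn2c(C)nc(C)c2C)=NC(C)=C(C(=O)OC)C1c1ccccc1Cl` — 5.01 nM
compound 3 `CCO/C(O)=C1\C(COCCN2CC(=O)N(C)C2=O)=NC(C)=C(C(=O)OC)C1c1cccc(Cl)c1Cl` — 5.01 nM

For the measured compounds named here, in a functional assay (aorta) with Rattus norvegicus as the target (a higher number here means a weaker inhibitor, a lower number a stronger inhibitor), compound 1 stands as the highest of the three numbers; compound 2 and compound 3 both sit lower by the same margin, and the only step bearing on the present change is a 5.0-fold lower number from compound 1 to compound 2 (0.70 log units; beyond the scatter), which swapped the same group on the same saturated chain carbon. Compound 4 `CCO/C(O)=C1\C(COCCn2nncc2C(N)=O)=NC(C)=C(C(=O)OC)C1c1ccccc1Cl` differs from compound 1 by a group of 8 heavy atoms (3 carbon, 4 nitrogen, 1 oxygen; one five-membered aromatic ring with 3 hetero atoms) in place of a group of 8 heavy atoms (4 carbon, 3 nitrogen, 1 oxygen; one five-membered aromatic ring with 2 hetero atoms), on a saturated chain carbon, two bonds along the chain from an oxygen on a saturated carbon. The entering 5-carbamoyl-1H-1,2,3-triazol-1-yl keeps the donor and acceptor count of the group that leaves, so no repeat of the size seen with compound 2 is assumed. The step of a 1.7-fold lower number from compound 1 to compound 4 (0.22 log units; within the scatter) is therefore expected to be small and possibly within the scatter, leaning toward a lower number. Compound 4 is estimated at 15 nM in this assay, with a range of 5 nM to 50 nM.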

Compound 4, half-maximal inhibitory concentration: 100 nM
Beside the measured number, compound 4's estimate is 6.7-fold (0.82 log units) below it, outside the stated range (above it).
By their numbers in this assay, from the lowest: compounds 2 and 3 (each within the scatter of the next); then compound 1; then compound 4.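

In this assay, the saturated chain carbon two bonds along the chain from an oxygen on a saturated carbon separates groups even when heavy-atom, donor and acceptor counts match: 5-carbamoyl-1H-1,2,3-triazol-1-yl gives a 4.0-fold higher number from compound 1 to compound 4 (0.60 log units; beyond the scatter). Against 2,4,5-trimethyl-1H-imidazol-1-yl, the same group gives a 20-fold higher number from compound 2 to compound 4 (1.30 log units; beyond the scatter), the largest step at this position so far. Nothing measured here accounts for these steps.

Still open, going by these compounds, is how much of the step belongs to the carbamoyl and how much to the triazole ring. A carboxylic acid or a methyl group in place of the carbamoyl would bear on that.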